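A few compounds are considered here, and "the series" means these few. Any claim that something is new, unique, unknown or untested is made for them only; others in the source may bear on it.

Of the compounds shown here, three sharing one core have been tested in an ADME assay on MT4 cells (Homo sapiens) for cytotoxicity, read by MTT assay; on this read-out lower numbers stand for higher toxicity in this test and higher numbers for lower toxicity in this test. Compound 1, with the structure `CCCC1C(=O)N(O)C(=O)c2ccccc21`, gives 25400 nM. Compound 2, `O=C1c2ccccc2C(Cc2ccccc2)C(=O)N1O`, gives 95000 nM, and compound 3, `CCCCCC1C(=O)N(O)C(=O)c2ccccc21`, gives 98300 nM. The change from compound 1 to compound 2 is phenyl in place of ethyl on a saturated chain carbon bound to a saturated ring carbon, and it brought a 3.7-fold higher number from compound 1 to compound 2 (0.57 log units; beyond the scatter). Lengthening the chain, (ethyl in place of hydrogen on a saturated chain carbon, three bonds along the chain from a saturated ring carbon), brought a 3.9-fold higher number from compound 1 to compound 3 (0.59 log units; beyond the scatter), while a 1.0-fold higher number from compound 2 to compound 3 (0.01 log units; within the scatter) shows compound 2 and compound 3 sit together.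

Compound 4, `O=C1c2ccccc2C(CCCc2ccccc2)C(=O)N1O`, is not yet measured in this assay. Its difference from compound 3 is phenyl in place of ethyl on a saturated chain carbon, three bonds along the chain from a saturated ring carbon. This is the same kind of change as from compound 1 to compound 2, though the place differs: there the carbon was bound to a saturated ring carbon, here it lies three bonds along the chain from a saturated ring carbon. The cores of compound 1 and compound 3 differ by ethyl in place of hydrogen on a saturated chain carbon, three bonds along the chain from a saturated ring carbon. The step from compound 3 to compound 4 in this assay is expected to be about a 1.2-fold higher number from compound 3 to compound 4 (0.09 log units; within the scatter), smaller than the earlier one, because compound 3 already gives 98300 nM and compound 2 gives 95000 nM, leaving little room. Compound 4 is therefore estimated at 120000 nM, between 40000 nM and 300000 nM.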

Compound 4, half-maximal cytotoxic concentration: 5200 nM
The estimate for compound 4 lay 23-fold (1.36 log units) above the measured number; the whole stated range lies above it.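

In this assay, the change from ethyl to phenyl does not carry over from one core to the other, and even its direction reverses: the same change on two cores in this assay, a 3.7-fold higher number (0.57 log units; beyond the scatter) from compound 1 to compound 2 and a 19-fold lower number (1.28 log units; beyond the scatter) from compound 3 to compound 4, 71-fold (1.85 log units) apart, beyond the scatter of two such steps

On the core of compound 3, the step is a 19-fold lower number from compound 3 to compound 4 (1.28 log units; beyond the scatter), and the number also falls relative to the shorter chain, with a 4.9-fold lower number from compound 1 to compound 4 (0.69 log units; beyond the scatter). This shows that the outcome of this change depends on the compound it is made on, but two pairs cannot explain the reversal or predict the change on any further core.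

The compounds shown leave open whether the low number of compound 4 belongs to phenyl at that place in particular, or would also appear with a longer chain, an amine or a carboxylic acid there. They also leave open how a phenyl group would behave on a chain of intermediate length, such as phenylethyl.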